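A few compounds are considered here, and "the series" means these few. Any claim that something is new, unique, unknown or untested is made for them only; others in the source may bear on it.

Of the compounds shown here, three that share one core have been tested in a functional assay on HCT-116 cells (Homo sapiens) for inhibition, with a stated time of 72 h; a lower number here means a stronger inhibitor, a higher number a weaker inhibitor: compound 1 `NC1CCC(Nc2nc(NCc3ccc(Br)cc3)c3ncn(C4CCCC4)c3n2)CC1`, compound 2 `NC1CCC(Nc2nc(NCc3ccc(-c4ccccc4)nc3)c3ncn(C4CCCC4)c3n2)CC1` and compound 3 `NC1CCC(Nc2nc(NCc3ccc(-c4ccsc4)nc3)c3ncn(C4CCCC4)c3n2)CC1`. Compound 1 gives 790 nM, compound 2 gives 563 nM, and compound 3 gives 145 nM. That last number is the lowest of the three, and the gaps from it to the other two lie beyond the scatter.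

The next compound, compound 4 `NC1CCC(Nc2nc(NCc3cc(Cl)ccc3O)c3ncn(C4CCCC4)c3n2)CC1`, has 5-chloro-2-hydroxyphenyl in place of 6-(thiophen-3-yl)pyridin-3-yl on a saturated chain carbon bound to a nitrogen on an aromatic ring.

Within the data shown here, three measured steps bear on this change. Exchanging 4-bromophenyl for 6-phenylpyridin-3-yl gave a 1.4-fold lower number from compound 1 to compound 2 (0.15 log units; within the scatter), whereas exchanging it for the group found in compound 3 gave a 5.4-fold lower number from compound 1 to compound 3 (0.74 log units; beyond the scatter). Thiophen-3-yl in place of phenyl accounts for a 3.9-fold lower number from compound 2 to compound 3 (0.59 log units; beyond the scatter). The advantage of compound 3 thus appeared only with thiophen-3-yl present, and compound 4 lacks that group. Among the measured compounds shown here, no tested compound carries 5-chloro-2-hydroxyphenyl, so this comparison is indirect.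

A modest rise in this assay is therefore expected, of about the size of these two larger steps: a 4.1-fold higher number from compound 3 to compound 4 (0.62 log units; beyond the scatter). The estimate for compound 4 is 600 nM, with an expected range from 200 nM to 2000 nM.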

Compound 4, half-maximal inhibitory concentration: 350 nM
Compound 4: middle estimate off by 1.7-fold (0.23 log units), on the high side; the range from low to high includes it.
By their numbers in this assay, from the lowest: compound 3; then compounds 4, 2 and 1 (each within the scatter of the next, the first and the last beyond it).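

In this assay, the 6-(thiophen-3-yl)pyridin-3-yl group of compound 3 keeps its lead over 5-chloro-2-hydroxyphenyl (a 2.4-fold higher number from compound 3 to compound 4 (0.38 log units; beyond the scatter)), but the new group shows that this place on the saturated chain carbon does not need a group with two aromatic rings to give a number in the same range as compound 2, since the step to compound 4 stays within the scatter (a 1.6-fold lower number from compound 2 to compound 4 (0.21 log units; within the scatter)). The earlier compounds shown here could not show this. Among these compounds, their only group with a single aromatic ring was the 4-bromophenyl of compound 1. Among the compounds shown here, that ring and the one in compound 4 are both six-membered and made of carbon only, yet they give clearly different numbers (a 2.3-fold lower number from compound 1 to compound 4 (0.35 log units; beyond the scatter)), so what the ring carries matters as well as how many rings the group has.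

Nothing measured here explains any of these differences. Compound 4 brings in its chlorine and its hydroxyl together, which leaves open how much each contributes alone, and what a methoxy group in place of the hydroxyl would do to the number.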